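Tert-butyl in place of difluoromethoxy: cytotoxicity on Vero cells

The source may hold more compounds than are shown below. What is called first, only, known or untested is meant among the compounds shown, and "the series" means these compounds.

Of the compounds shown here, three built on one shared core have been tested for toxicity toward cultured cells in an ADME assay on Vero cells (Chlorocebus sabaeus) for cytotoxicity, read by resazurin assay, with a stated time of 3 days; a lower number here means a stronger inhibitor, a higher number a weaker inhibitor. Compound 1 `CN(C)c1cc2[nH]c(C3CCCCC3)nc2cc1NC(=O)c1cccs1` carries a thiophen-2-yl on its carbonyl carbon, compound 2 `CN(C)c1cc2[nH]c(C3CCCCC3)nc2cc1NC(=O)c1ccc(Br)cc1` a 4-bromophenyl and compound 3 `CN(C)c1cc2[nH]c(C3CCCCC3)nc2cc1NC(=O)c1ccc(OC(F)F)cc1` a 4-(difluoromethoxy)phenyl. In this assay compound 1 gives > 100 ug/mL, which is a limit of the assay rather than a number. Compound 2 likewise gives > 100 ug/mL, again a limit. Compound 3 gives > 100 ug/mL, also a limit. The steps among them, a step that the two limits leave unreadable from compound 1 to compound 2, a step that the two limits leave unreadable from compound 1 to compound 3 and a step that the two limits leave unreadable from compound 2 to compound 3, cannot be sized because of the limit of > 100 ug/mL in this assay, at which 3 of the 3 values shown sit. Compound 3 thus stands where every value shown stands, at the limit of the assay, with no number of its own.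

Compound 4 `CN(C)c1cc2[nH]c(C3CCCCC3)nc2cc1NC(=O)c1ccc(C(C)(C)C)cc1` differs from compound 3 in one place: tert-butyl in place of difluoromethoxy on an aromatic carbon. Among the measured compounds shown here, none of the measured steps has a readable size, so none can point in a direction; what they do show is that three different groups on the carbonyl carbon all left the value at the limit. The expected step is therefore a number no higher from compound 3 to compound 4 (the limit leaves the size open), meaning no change this assay could resolve. Compound 4 is accordingly estimated at 100 ug/mL, between 40 ug/mL and 250 ug/mL, and most likely reported once more only as a limit.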

Compound 4, half-maximal inhibitory concentration: > 100 ug/mL
Compound 4: only a limit was reported; the forecaster's own chance of this, stated with the estimate: 70%; the middle value lies on the limit itself.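

No step between compound 4 and compound 1, compound 2 or compound 3 can be read, because each value is a limit of the assay and not a number: the limit of > 100 ug/mL in this assay, at which 4 of the 4 values shown sit.

The compounds shown leave open what number any of them would have in this assay, and whether any group on the carbonyl carbon changes that number at all.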